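Swapping the Sulfur-Bound Ring in a Chloro Compound

A few compounds are considered here, and "the series" means these few. Any claim that something is new, unique, unknown or untested is made for them only; others in the source may bear on it.

In a functional assay on C6 cells (Rattus norvegicus) for cytotoxicity, read by MTT assay, with a stated time of 24 h (on this read-out lower numbers stand for stronger inhibition and higher numbers for weaker inhibition), compound 1 (`Cc1nnc(SCC(=O)N/N=c2/scc(-c3ccccc3)n2-c2ccccc2)s1`) gives > 200 ug/mL, which is a limit of the assay and not a number. Among the compounds with values here, compound 2 (`Cc1nnc(SCC(=O)N/N=c2/scc(-c3ccc(Cl)cc3)n2-c2ccccc2)s1`) gives 28 ug/mL, the only actual number so far. Chloro in place of hydrogen on an aromatic carbon produced an at least 7.1-fold lower number from compound 1 to compound 2 (0.85 log units; beyond the scatter), a step beyond the scatter. The size of that step depends on compound 1 and on (the limit of > 200 ug/mL in this assay, at which 1 of the 2 values shown sits).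

Compound 3 (`O=C(CSc1ncccn1)N/N=c1/scc(-c2ccc(Cl)cc2)n1-c1ccccc1`) keeps the chloro but changes another part of the molecule: pyrimidin-2-yl in place of 5-methyl-1,3,4-thiadiazol-2-yl on a sulfur. In words, pyrimidin-2-yl stands in place of 5-methyl-1,3,4-thiadiazol-2-yl on a sulfur. Within the data shown here, no measured step covers this swap, so no direction can be argued, and no change beyond the scatter is expected, though the uncertainty is wide. The estimated change is a 1.4-fold higher number from compound 2 to compound 3 (0.15 log units; within the scatter). For compound 3 the expected value is 40 ug/mL, with an estimated range of 12 ug/mL to 150 ug/mL.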

Compound 3, half-maximal inhibitory concentration: 83.3 ug/mL
Compound 3: middle estimate off by 2.1-fold (0.32 log units), on the low side; measured number inside the range.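

In this assay the swap of pyrimidin-2-yl in place of 5-methyl-1,3,4-thiadiazol-2-yl on a sulfur, with the chloro kept, gave a 3.0-fold higher number from compound 2 to compound 3 (0.47 log units; beyond the scatter) and so moved the number beyond the scatter. Within the data shown here, until this point only the chloro change had a measured step, so this is the first sign that the ring on the sulfur matters too, with the 5-methyl-1,3,4-thiadiazol-2-yl group giving the lower number of this one pair. Nothing measured here explains why these two rings differ.

On these data alone, whether the same swap has the same effect without the chloro remains open. So does the outcome with a different group on the sulfur, such as a plain phenyl ring or an open alkyl chain carrying an amine.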